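Compound 4: chloro replaces nitro on the outer phenyl ring

The source may hold more compounds than are shown below. What is called first, only, known or untested is meant among the compounds shown, and "the series" means these compounds.

Three members of the series have numbers in an assay on CHO-K1 cells for displacement of a labelled ligand from adenosine receptor A1 (Homo sapiens), tested at 10 uM; on this read-out higher numbers stand for more inhibition at the one concentration tested (going by the name of the read-out) and lower numbers for less inhibition. Compound 1 `Nc1sc(-c2ccccc2)c(-c2cccc(C(F)(F)F)c2)c1C(=O)c1ccccc1` gives 82.4%. Compound 2 `CC(=O)c1ccc(-c2sc(N)c(C(=O)c3ccccc3)c2-c2cccc(C(F)(F)F)c2)cc1` gives 25.6%, and compound 3 `Nc1sc(-c2ccc([N+](=O)[O-])cc2)c(-c2cccc(C(F)(F)F)c2)c1C(=O)c1ccccc1` gives 34.8%. On these three numbers compound 3 stands second highest: its nearest neighbour is compound 2, a number 9.2 percentage points higher from compound 2 to compound 3 (within the scatter), and its furthest is compound 1, a number 47.6 percentage points lower from compound 1 to compound 3 (beyond the scatter).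

Compound 4 `Nc1sc(-c2ccc(Cl)cc2)c(-c2cccc(C(F)(F)F)c2)c1C(=O)c1ccccc1` is not yet measured. It differs from compound 3 in one place: chloro in place of nitro on an aromatic carbon.

Going by the values given here, no measured step puts chloro in this position. Among the compounds with values here, the steps that bear on it are the two that fill the same aromatic carbon from hydrogen: a number 56.8 percentage points lower from compound 1 to compound 2 (beyond the scatter) and a number 47.6 percentage points lower from compound 1 to compound 3 (beyond the scatter), both large and both downward, while a number 9.2 percentage points higher from compound 2 to compound 3 (within the scatter) shows the two filled cases within the scatter of each other. Compound 4 lies between the filled and the unfilled case in what is known, so in this assay an upward step of moderate size is expected, a number 15.2 percentage points higher from compound 3 to compound 4 (beyond the scatter), with wide uncertainty. The estimate for compound 4 is therefore 50%, in the range 25% to 78%.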

Compound 4, a percentage reported as inhibition, at one concentration (the size of the read-out at that concentration, not a potency): 59.1%
Beside the measured number, compound 4's estimate is 9.1 percentage points below it, within the range that was stated.
By their numbers in this assay, from the lowest: compounds 2 and 3 (each within the scatter of the next); then compound 4; then compound 1.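

In this assay the groups on this aromatic carbon no longer fall together: chloro in place of nitro gives a number 24.3 percentage points higher from compound 3 to compound 4 (beyond the scatter), and chloro in place of acetyl gives a number 33.5 percentage points higher from compound 2 to compound 4 (beyond the scatter). Chloro in place of hydrogen still gives a number 23.3 percentage points lower from compound 1 to compound 4 (beyond the scatter), so all three groups shown here lower the number relative to hydrogen, but by different amounts. Nothing available accounts for the separation of chloro from nitro and acetyl.

The compounds shown leave open where an amine, a methoxy group, a carboxylic acid, fluoro or bromo would fall at this position. They also leave open whether the step from 4-nitrophenyl to 4-chlorophenyl holds when another group stands in place of trifluoromethyl.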